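Ring Amine Methylation in a Cytotoxic Series

The source may report more compounds than this note shows. Statements on the series, on what has been measured and on what is new or still open speak of the compounds shown alone.

Of the compounds shown here, two built on one shared core have been tested in a functional assay on Caov-3 cells (Homo sapiens) for cytotoxicity, read by MTT assay, with a stated time of 72 h; on this read-out higher numbers stand for weaker inhibition and lower numbers for stronger inhibition. Compound 1 `O=C1/C(=C/c2cccnc2)CNC/C1=C\c1cccnc1` gives 9200 nM in this assay. Compound 2 `O=C1/C(=C/c2ccncc2)CNC/C1=C\c1ccncc1` gives 6000 nM in this assay. On the numbers shown, compound 2 has the value nearest to that of compound 1, and the two lie within the usual scatter of each other, so neither can be called the more active of the pair, and nothing is known of any single step between them.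

Compound 3 `CN1C/C(=C\c2ccncc2)C(=O)/C(=C/c2ccncc2)C1` has not yet been measured. It differs from compound 2 only by methyl in place of hydrogen on an amine nitrogen in a ring. No step of this kind exists among the measured compounds, so there is no shown step to lean on; the data simply lack it. With nothing to point in either direction, the author expects the step of no change at the digits printed from compound 2 to compound 3 (within the scatter) to fall within the scatter, neither a gain nor a loss beyond it. Compound 3 is accordingly estimated at 6000 nM in this assay, with a range from 2000 nM to 18000 nM.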

Compound 3, half-maximal inhibitory concentration: 5100 nM
Compound 3: the middle estimate sits 1.2-fold (0.07 log units) above what was measured; measured number inside the range.
By their numbers in this assay, from the lowest: compounds 3, 2 and 1 (each within the scatter of the next).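

Going by these compounds alone, the step of a 1.2-fold lower number from compound 2 to compound 3 (0.07 log units; within the scatter) in this assay gives the first reading of any change at this position, which the earlier compounds could not provide. It shows that, with the rest of compound 2 held fixed, methyl can take the place of hydrogen on this amine nitrogen in a ring without a shift beyond the scatter, so this read-out does not separate the two compounds and the hydrogen on that nitrogen is not needed to keep the value within that scatter. Within the data shown here, nothing measured here gives a reason for this outcome, and the single step shows only that this one small replacement leaves the number within the scatter.

As far as these compounds go, it remains open whether this tolerance extends to larger or different groups on the same nitrogen, such as an ethyl or benzyl group, a longer chain ending in a carboxylic acid, or an acetyl group forming an amide. It is equally open whether methyl on the nitrogen of compound 1 would give a similar step, since the one step shown starts from compound 2 alone.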